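Diaryl methane series: alkyl replacement for methoxymethyl branch

The source may hold more compounds than are shown below. What is called first, only, known or untested is meant among the compounds shown, and "the series" means these compounds.

Measured so far:
compound 1 `CCCCC[C@H](C(C)C)C(c1ccc(O)c(OC)c1)c1ccc(O)c(OC)c1` 9200 nM
compound 2 `COC[C@@H](C)[C@H](C)C(c1ccc(O)c(OC)c1)c1ccc(O)c(OC)c1` 58000 nM
compound 3 `COc1cc(C(c2ccc(O)c(OC)c2)[C@H](CC(C)C)C(C)C)ccc1O` 8200 nM

In a functional assay on HeLa cells (Homo sapiens) for cytotoxicity, read by WST assay, with a stated time of 48 h (a higher number here means a weaker inhibitor, a lower number a stronger inhibitor), compound 2 gives the highest number of the three, compound 1 the nearest and compound 3 the furthest. Compound 4 `CC[C@H](C(C)C)C(c1ccc(O)c(OC)c1)c1ccc(O)c(OC)c1` is not yet measured. Its change from compound 2: 1-isopropylpropyl in place of 2-(methoxymethyl)-1-methylpropyl on a saturated chain carbon bound to two aromatic carbons. For the measured compounds named here, two measured steps bear on it, both removing the same methoxymethyl-bearing branch in favour of a branched alkyl chain: a 6.3-fold higher number from compound 1 to compound 2 (0.80 log units; beyond the scatter) and a 7.1-fold lower number from compound 2 to compound 3 (0.85 log units; beyond the scatter). The step to compound 4 is of the same kind, with a shorter chain than in compounds 1 and 3, so a drop of modest size is expected, a 4.8-fold lower number from compound 2 to compound 4 (0.68 log units; beyond the scatter). For compound 4 the estimate in this assay is 12000 nM, within 6000 nM to 30000 nM.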

Compound 4, half-maximal inhibitory concentration: 9700 nM
Estimate against measurement, compound 4: 1.2-fold (0.09 log units) above; low and high end bracket the measured number.
By their numbers in this assay, from the lowest: compounds 3, 1 and 4 (each within the scatter of the next); then compound 2.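

In this assay the replacement of 2-(methoxymethyl)-1-methylpropyl by an all-carbon branched group also holds for 1-isopropylpropyl, with a 6.0-fold lower number from compound 2 to compound 4 (0.78 log units; beyond the scatter). Chain size on the saturated chain carbon bound to two aromatic carbons has no readable effect across these alkyl groups, since a 1.2-fold higher number from compound 3 to compound 4 (0.07 log units; within the scatter) and a 1.1-fold higher number from compound 1 to compound 4 (0.02 log units; within the scatter) both lie within the scatter. No supporting data explain this flat alkyl range or the higher number of compound 2.

Still open, going by these compounds, is whether a hydroxyl, an amine or a carboxylic acid on this chain would behave like the methoxymethyl branch. Also open, on these data alone, is whether a group smaller than 1-isopropylpropyl, or a chain ending in a phenyl ring, would move the number.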